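Methoxy for Ethoxycarbonyl on the Urea Aryl Ring

The source may report more compounds than this note shows. Statements on the series, on what has been measured and on what is new or still open speak of the compounds shown alone.

Of the compounds shown here, two have been measured in a functional assay on HT-29 cells (Homo sapiens) for inhibition, read by luminescence and CellTiter-Glo, with a stated time of 12 h; a lower number here means that less compound is needed, a higher number that more compound is needed for the effect. Compound 1 `O=C(CCc1cccc(C(F)(F)F)c1)Nc1cc(Oc2ccc3nc(NC(=O)C4CC4)sc3c2)ccc1F` gives 650 nM. Compound 2 `CCOC(=O)c1cccc(NC(=O)Nc2cc(Oc3ccc4nc(NC(=O)C5CC5)sc4c3)ccc2F)c1` gives 7740 nM, the higher of the two numbers; the change from compound 1 to compound 2 replaced the carbonyl substituent, and a 12-fold higher number from compound 1 to compound 2 (1.08 log units; beyond the scatter). Compound 3 `COc1cccc(NC(=O)Nc2cc(Oc3ccc4nc(NC(=O)C5CC5)sc4c3)ccc2F)c1` is not yet measured. It differs from compound 2 in one place: methoxy in place of ethoxycarbonyl on an aromatic carbon, on an aromatic carbon of a six-membered aromatic ring of carbon only, meta to a large group. Within the data shown here, no measured step alters this ring; the single step from compound 1 to compound 2 rebuilt the whole amine side at once, so it does not isolate the effect of the ethoxycarbonyl group, and it gives no direction for the present change. The expectation must therefore be wide. Compound 3 is estimated at 5000 nM, within 1000 nM to 25000 nM. That estimate means a step of a 1.5-fold lower number from compound 2 to compound 3 (0.19 log units; within the scatter), which is expected to stay near the scatter rather than to repeat the large step seen before.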

Compound 3, half-maximal effective concentration: 1370 nM
The estimate for compound 3 lay 3.6-fold (0.56 log units) above the measured number; low and high end bracket the measured number.
By their numbers in this assay, from the lowest: compound 1; then compound 3; then compound 2.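

In this assay, methoxy in place of ethoxycarbonyl on an aromatic carbon, meta to a large group, gives a 5.6-fold lower number from compound 2 to compound 3 (0.75 log units; beyond the scatter) with all else held fixed, so this position affects the number independently of the rest of the amine side, which the earlier step could not show. Compound 3 also changes how the earlier step reads: a 2.1-fold higher number from compound 1 to compound 3 (0.32 log units; beyond the scatter) is a modest step and remains beyond the scatter, whereas the rebuilt side carrying ethoxycarbonyl gave a 12-fold higher number from compound 1 to compound 2 (1.08 log units; beyond the scatter) as a large step, so the size of that earlier step depended on the ring substituent as well as on the change at the carbonyl carbon. Nothing measured here explains why methoxy goes with the lower number.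

On these data alone, it remains open whether the number follows the size of the group or its identity, a question that an amine, a carboxylic acid or a longer alkoxy chain on this aromatic carbon would help to settle. As far as these compounds go, it is also open whether trifluoromethyl on this ring of the urea series would close the remaining gap to compound 1.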